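Testing the Mirror Image of Compound 2

A few compounds are considered here, and "the series" means these few. Any claim that something is new, unique, unknown or untested is made for them only; others in the source may bear on it.

Of the compounds shown here, two have been measured in a functional assay on MDA-MB-231 cells (Homo sapiens) for inhibition, read by MTT assay, with a stated time of 72 h (a higher number here means a weaker inhibitor, a lower number a stronger inhibitor), so far. Compound 1 (`CC1=NN(c2ccccc2)C(=O)[C@@]12C(=O)C=CC[C@@H]2c1ccccc1[N+](=O)[O-]`) reads 68300 nM there, while compound 2 (`CC1=NN(c2ccccc2)C(=O)[C@]12C(=O)C=CC[C@H]2c1cccc(C)c1`) reads 10300 nM as the lower of the two numbers, with a gap between them that lies beyond the scatter. Compound 2 is thus the stronger inhibitor of this pair, although two compounds alone show no trend.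

Compound 3 (`CC1=NN(c2ccccc2)C(=O)[C@@]12C(=O)C=CC[C@@H]2c1cccc(C)c1`) has not yet been measured in this assay and differs from compound 2 by the two compounds have the same atoms and bonds and differ only in configuration as drawn: 2 of 2 stereo elements differ (all stereocentres are inverted: mirror images); a stereocentre at a saturated ring carbon is drawn S in compound 2 and R in compound 3; a stereocentre at a saturated ring carbon is drawn S in compound 2 and R in compound 3 in the way it is drawn. The two have the same atoms and bonds, all stereocentres are inverted, and they are mirror images. Going by the values given here, no measured pair shows what such an inversion does, so the data offer no firm direction. No step beyond the scatter is expected, and the estimate is a 1.4-fold higher number from compound 2 to compound 3 (0.13 log units; within the scatter) as the most likely outcome. For compound 3 the estimated value is 14000 nM within an expected range from 5000 nM to 40000 nM in this measurement.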

Compound 3, half-maximal inhibitory concentration: 6800 nM
Compound 3: the middle estimate sits 2.1-fold (0.31 log units) above what was measured, within the range that was stated.
By their numbers in this assay, from the lowest: compounds 3 and 2 (each within the scatter of the next); then compound 1.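

In this assay, inverting both stereocentres of the 3-methylphenyl compound gives a 1.5-fold lower number from compound 2 to compound 3 (0.18 log units; within the scatter), so this pair of mirror images cannot be told apart in this measurement, which is something the first two compounds could not show. This reading of the pair is a clean one, as only the drawn configuration separates the two: the fact that compounds 2 and 3 differ only in the configuration as drawn. The new compound also isolates the change of group on the saturated ring carbon, which earlier came together with an inversion of configuration: with the configuration as drawn held constant, 3-methylphenyl in place of 2-nitrophenyl gives a 10-fold lower number from compound 1 to compound 3 (1.00 log units; beyond the scatter), a modest step beyond the scatter.

With a single pair of mirror images, the compounds shown leave open whether inversion would be equally silent in the 2-nitrophenyl compound, where the same change might read differently. They also leave open how the number would move with a phenyl group carrying an amine or a carboxylic acid on this saturated ring carbon, and whether the step seen here belongs to the 3-methylphenyl group alone or to the removal of the nitro group.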